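The source may report more compounds than this note shows. Statements on the series, on what has been measured and on what is new or still open speak of the compounds shown alone.

In an ADME assay on Vero cells (Chlorocebus sabaeus) for cytotoxicity, read by MTT assay, with a stated time of 48 h (on this read-out higher numbers stand for weaker inhibition and lower numbers for stronger inhibition), compound 3 `CN(Cc1ccccc1)c1cc(=O)c2cc(C(F)(F)F)cc([N+](=O)[O-])c2s1` gives > 64 ug/mL, which is a limit of the assay rather than a measured number. Compound 1 `O=c1cc(NCc2ccccc2)sc2c([N+](=O)[O-])cc(C(F)(F)F)cc12` gives > 64 ug/mL, again a limit. Compound 2 `O=c1cc(NCc2cccc(F)c2)sc2c([N+](=O)[O-])cc(C(F)(F)F)cc12` gives > 64 ug/mL, also a limit. Going by the values given here, every value so far is therefore (the limit of > 64 ug/mL in this assay, at which 3 of the 3 values shown sit), so none of the three compounds can be placed in order against the others.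

Compound 4 `O=c1cc(NC2CCCCC2)sc2c([N+](=O)[O-])cc(C(F)(F)F)cc12` differs from compound 3 in one place: cyclohexylamino in place of benzyl(methyl)amino on an aromatic carbon. The measured steps that touch the amine are a step that the two limits leave unreadable from compound 1 to compound 3 and a step that the two limits leave unreadable from compound 2 to compound 3, and the remaining step that the two limits leave unreadable from compound 1 to compound 2 is no more informative; each joins two limits, so no size or direction can be read from any of them. Nothing measured here points to a cytotoxic effect appearing on changing the amine substituent.

Compound 4 is therefore expected to sit at the same limit, with an estimate of 64 ug/mL, between 40 ug/mL and 100 ug/mL, and an expected step of a number no higher from compound 3 to compound 4 (the limit leaves the size open) that is most likely again unreadable.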

Compound 4, half-maximal inhibitory concentration: > 64 ug/mL
Compound 4: only a limit was reported (the forecaster's own chance of this, stated with the estimate: 85%); the middle value lies on the limit itself.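

In this assay compound 4 gives > 64 ug/mL, which is a limit, so the steps joining compound 4 to compound 1, compound 2 and compound 3 cannot be read: the limit of > 64 ug/mL in this assay, at which 4 of the 4 values shown sit.

The compounds shown leave open whether changing the amine substituent affects cytotoxicity at all.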